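Removing a Vinyl Group from a Four-Membered Ring

This account rests on a few compounds, and the source may have more. Where it says the series, first, only, none or still open, it means among the compounds named here.

Measured compounds:
Compound 1, `COc1cc(N2C(=O)CC2c2ccc(SC)cc2)cc(OC)c1OC`: in a functional assay on HL-60 cells (Homo sapiens) for inhibition, read by resazurin assay, with a stated time of 72 h (a lower number here means a stronger inhibitor, a higher number a weaker inhibitor), compound 1 gives 69 nM.
Compound 2, `C=CC1C(=O)N(c2cc(OC)c(OC)c(OC)c2)C1c1ccc(SC)cc1`: compound 2 gives 61 nM.
Compound 3, `C=CC1C(=O)N(c2cc(OC)c(OC)c(OC)c2)C1c1ccc(OC)cc1`: compound 3 gives 33 nM.

The three compounds share one core and differ in two places. Compound 2 and compound 3 differ in that (methoxy in place of methylsulfanyl on an aromatic carbon), and this gives a 1.8-fold lower number from compound 2 to compound 3 (0.27 log units; within the scatter). Compound 2 and compound 1 differ in that (hydrogen in place of vinyl on a saturated ring carbon), which gives a 1.1-fold higher number from compound 2 to compound 1 (0.05 log units; within the scatter). Compound 3 shows the lowest of the three numbers, but its gap to compound 2 lies within the scatter, so no order between those two can be read from the data.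

Compound 4, `COc1ccc(C2CC(=O)N2c2cc(OC)c(OC)c(OC)c2)cc1`, has not yet been measured in this assay. It differs from compound 3 in that (hydrogen in place of vinyl on a saturated ring carbon). Among the compounds with values here, this is the same kind of change as the one from compound 2 to compound 1, though not the same: in compound 3 the changed carbon is next to the ring atom that bears a 4-methoxyphenyl group, whereas in compound 2 that ring atom bears a 4-(methylsulfanyl)phenyl group. Because the earlier step of a 1.1-fold higher number from compound 2 to compound 1 (0.05 log units; within the scatter) lay within the scatter, the step from compound 3 to compound 4 is expected to be small as well, about a 1.1-fold higher number from compound 3 to compound 4 (0.05 log units; within the scatter). Compound 4 is therefore estimated to give around 37 nM, expected to fall between 16 nM and 90 nM.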

Compound 4, half-maximal inhibitory concentration: 76 nM
Estimate against measurement, compound 4: 2.1-fold (0.31 log units) below, within the range that was stated.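

In this assay, taking the vinyl group off the four-membered ring gives a 2.3-fold higher number from compound 3 to compound 4 (0.36 log units; beyond the scatter), while the same change on the other core gave a 1.1-fold higher number from compound 2 to compound 1 (0.05 log units; within the scatter), yet these two steps cannot be told apart: the same change on two cores in this assay, a 1.1-fold higher number (0.05 log units; within the scatter) from compound 2 to compound 1 and a 2.3-fold higher number (0.36 log units; beyond the scatter) from compound 3 to compound 4, 2.0-fold (0.31 log units) apart, within the scatter of two such steps

Putting methoxy in place of methylsulfanyl on the compounds without the vinyl group gives a 1.1-fold higher number from compound 1 to compound 4 (0.04 log units; within the scatter), and this step also agrees with its earlier counterpart: the same change on two cores in this assay, a 1.8-fold lower number (0.27 log units; within the scatter) from compound 2 to compound 3 and a 1.1-fold higher number (0.04 log units; within the scatter) from compound 1 to compound 4, 2.0-fold (0.31 log units) apart, within the scatter of two such steps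

So both changes carry from one core to the other as far as measurements of this kind can resolve, but this rests on a single pair of steps for each change. The data do not show that losing the vinyl group matters more in the compounds with the 4-methoxyphenyl group than in those with the 4-(methylsulfanyl)phenyl group, nor that the same agreement would hold on any further core.

On these data alone, only hydrogen and vinyl appear on this saturated ring carbon, so it remains open how an ethyl group, a longer chain or a hydroxymethyl group would behave there. Only methoxy and methylsulfanyl appear on the aromatic carbon, which leaves open what an amine or a chlorine atom would do in their place.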